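Methyl substitution in a series without measurable cytotoxicity

The source may report more compounds than this note shows. Statements on the series, on what has been measured and on what is new or still open speak of the compounds shown alone.

Measured so far:
- Compound 1, `O=c1cc(CSc2nc3ccccc3s2)oc2ccccc12`; in a functional assay on HEp-2 cells (Homo sapiens) for cytotoxicity, read by MTT assay, with a stated time of 72 h (on this read-out higher numbers stand for weaker inhibition and lower numbers for stronger inhibition), compound 1 gives only a limit, > 25000 nM.
- Compound 2, `Cc1nnc(SCc2cc(=O)c3ccccc3o2)s1`; in this assay compound 2 gives only a limit, > 25000 nM.
- Compound 3, `Cc1ccc2oc(CSc3nc4ccccc4s3)cc(=O)c2c1`; in this assay compound 3 gives only a limit, > 25000 nM.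

The difference between the cores of compound 1 and compound 2 is not broken down here. Compound 3 arises from compound 1 by methyl in place of hydrogen on an aromatic carbon, and the resulting step is a step that the two limits leave unreadable from compound 1 to compound 3, because of the limit of > 25000 nM in this assay, at which 3 of the 3 values shown sit.

Compound 4, `Cc1ccc2oc(CSc3nnc(C)s3)cc(=O)c2c1`, is not yet measured. It arises from compound 2 by methyl in place of hydrogen on an aromatic carbon, the same change as that from compound 1 to compound 3, made on the core of compound 2 instead.

For compound 4 a step that the limit leaves unreadable from compound 2 to compound 4 is expected in this assay, beside the earlier step that the two limits leave unreadable from compound 1 to compound 3; this expectation rests on (the limit of > 25000 nM in this assay, at which 3 of the 3 values shown sit), at which compound 2 and compound 3 both sit. Compound 4 is therefore estimated at 40000 nM, most likely again reported only as a limit.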

Compound 4, half-maximal inhibitory concentration: > 25000 nM
Compound 4: no number, only a limit; the forecaster's own chance of this, stated with the estimate: 85%; the middle value lies beyond the limit too.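

In this assay compound 4 gives only a limit, > 25000 nM. The steps from compound 2 to compound 4 and from compound 1 to compound 3 therefore cannot be read, because both ends of each are limits: the limit of > 25000 nM in this assay, at which 4 of the 4 values shown sit.

The compounds shown leave open whether methyl in place of hydrogen changes cytotoxicity on either core.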